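The source may report more compounds than this note shows. Statements on the series, on what has been measured and on what is new or still open speak of the compounds shown alone.

Measured so far in a functional assay on PC-3 cells (Homo sapiens) for cytotoxicity, read by MTT assay, with a stated time of 72 h; on this read-out lower numbers stand for stronger inhibition and higher numbers for weaker inhibition:

- compound 1, `O=C(Nc1ccc(Oc2ccnc3[nH]ccc23)cc1)c1nn(-c2ccc(Br)cc2)ccc1=O`: 8040 nM
- compound 2, `O=C(Nc1ccc(Oc2ccnc3[nH]ccc23)c(F)c1)c1nn(-c2ccc(Br)cc2)ccc1=O`: 40800 nM
- compound 3, `O=C(Nc1ccc(Oc2ccnc3[nH]ccc23)c(F)c1)c1nn(-c2ccc(Br)cc2F)ccc1=O`: 8800 nM

Compound 2 gives the highest of the three numbers in this assay. The step of a 5.1-fold higher number from compound 1 to compound 2 (0.71 log units; beyond the scatter) is beyond the scatter, and the step of a 4.6-fold lower number from compound 2 to compound 3 (0.67 log units; beyond the scatter) runs the other way and is also beyond the scatter; both are of modest size and both introduce fluoro in place of hydrogen on an aromatic carbon.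

Compound 4, `Cn1ccc2c(Oc3ccc(NC(=O)c4nn(-c5ccc(Br)cc5)ccc4=O)cc3F)ccnc21`, differs from compound 2 in one place: methyl in place of hydrogen on an aromatic nitrogen. Going by the values given here, neither measured step touches this part of the core, so there is no direct precedent for methyl entering on an aromatic nitrogen of the five-membered ring. The two measured steps show only that single small substitutions in this series have moved this assay by modest amounts in either direction. The expectation for compound 4 is therefore a step of at most modest size, direction uncertain, and possibly none beyond the scatter; the estimated step is a 2.0-fold lower number from compound 2 to compound 4 (0.31 log units; beyond the scatter). Compound 4 is expected to give about 20000 nM in this assay, within a range from 5000 nM to 80000 nM.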

Compound 4, half-maximal inhibitory concentration: > 60000 nM
Compound 4: only a limit was reported; the forecaster's own chance of this, stated with the estimate: 15%; middle value at least 3.0-fold (0.47 log units) away from the limit.
By their numbers in this assay, from the lowest: compounds 1 and 3 (each within the scatter of the next); then compound 2. At a limit, above all of these: compound 4.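

Compound 4 carries a limit of the assay rather than a number in this assay: the limit of > 60000 nM in this assay, at which 1 of the 4 values shown sits.

Going by these compounds alone, this is the only reading at the aromatic nitrogen of the five-membered aromatic ring, and methyl in place of hydrogen there gives an at least 1.4-fold higher number from compound 2 to compound 4 (0.16 log units; that floor lies within the scatter), so only a floor for the step is known and its true size cannot be read. The two fluoro steps moved the number in opposite directions, whereas this change shows no lowering of the number, even though compound 2 already gives the highest measured number of the series.

The compounds shown leave open whether the hydrogen on this nitrogen matters at all, or whether the step is larger than its floor suggests, and a longer chain such as ethyl or a 2-hydroxyethyl group on the same nitrogen would help to tell these apart. They also leave open whether methyl on this nitrogen would act the same way on the cores of compound 1 and compound 3, whose numbers lie within the scatter of each other.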